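Extending the Amide Substituent from Isopropyl to Butyl

The compounds below may be only part of what the source reports. "The series", "measured", "known", "first", "only" and "open" are said of these compounds alone.

The measured compounds share one core and differ only in the group on the amide-type nitrogen:

compound 1, `CNC(=O)CC[C@H](NS(=O)(=O)c1ccc([N+](=O)[O-])cc1)C(=O)O`, giving 7500 nM in an assay for inhibition of matrix metalloproteinase-9 (Homo sapiens), with stated times of 1 h, 1 min and 30 min; on this read-out higher numbers stand for weaker inhibition and lower numbers for stronger inhibition
compound 2, `CCNC(=O)CC[C@H](NS(=O)(=O)c1ccc([N+](=O)[O-])cc1)C(=O)O`, giving 4800 nM in this assay
compound 3, `CC(C)NC(=O)CC[C@H](NS(=O)(=O)c1ccc([N+](=O)[O-])cc1)C(=O)O`, giving 5970 nM in this assay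

Compound 3 stands second highest of the three numbers; its nearest neighbour is compound 2, at a 1.2-fold higher number from compound 2 to compound 3 (0.09 log units; within the scatter), and its furthest is compound 1, at a 1.3-fold lower number from compound 1 to compound 3 (0.10 log units; within the scatter), so all three sit within the scatter of one another.

Compound 4, `CCCCNC(=O)CC[C@H](NS(=O)(=O)c1ccc([N+](=O)[O-])cc1)C(=O)O`, has not yet been measured. It differs from compound 3 by butyl in place of isopropyl on an amide-type nitrogen, the fourth change of this kind along the series. Within the data shown here, the steps that bear on it are a 1.6-fold lower number from compound 1 to compound 2 (0.19 log units; within the scatter) and a 1.3-fold lower number from compound 1 to compound 3 (0.10 log units; within the scatter), both within the scatter, as is a 1.2-fold higher number from compound 2 to compound 3 (0.09 log units; within the scatter). Growing the alkyl on the amide-type nitrogen has so far moved nothing beyond the scatter, so no step beyond it is expected here either. Compound 4 is therefore estimated at 5000 nM, with a range from 2500 nM to 10000 nM. That estimate means an expected step of a 1.2-fold lower number from compound 3 to compound 4 (0.08 log units; within the scatter).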

Compound 4, half-maximal inhibitory concentration: 6360 nM
The estimate for compound 4 lay 1.3-fold (0.10 log units) below the measured number; the measured number falls inside the stated range.
By their numbers in this assay, from the lowest: compounds 2, 3, 4 and 1 (each within the scatter of the next).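

Butyl on the amide-type nitrogen is the longest alkyl group shown, yet compound 4 stays within the scatter of all three earlier compounds in this assay (a 1.1-fold higher number from compound 3 to compound 4 (0.03 log units; within the scatter); a 1.3-fold higher number from compound 2 to compound 4 (0.12 log units; within the scatter); a 1.2-fold lower number from compound 1 to compound 4 (0.07 log units; within the scatter)). The earlier compounds shown here covered only methyl, ethyl and isopropyl, so the new result extends the flat picture to butyl: exchanging branched isopropyl for this unbranched chain produces no step beyond the scatter, and none of the four alkyl groups separates from the others at this position. No measurement available here accounts for this flat result.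

The compounds leave open whether a still longer chain, such as octyl, would move the number beyond the scatter at this place. They also leave open what an amine or a carboxylic acid at the end of the butyl chain would do.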